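This account rests on a few compounds, and the source may have more. Where it says the series, first, only, none or still open, it means among the compounds named here.

Compound 1 `O=C(COc1cccc2ccccc12)N/N=C/c1ccccc1O`: 3.57 ug/mL
Compound 2 `O=C(COc1cccc2ccccc12)N/N=C/c1ccccc1[N+](=O)[O-]`: 100 ug/mL
Compound 3 `Cc1ccc(/C=N/NC(=O)COc2cccc3ccccc23)cc1`: not yet measured

Among the compounds with values here, in an ADME assay on HEL cells (Homo sapiens) for cytotoxicity (on this read-out higher numbers stand for lower toxicity in this test and lower numbers for higher toxicity in this test), compound 1 gives 3.57 ug/mL, the lower of the two numbers so far. The structural change to compound 3 is 4-methylphenyl in place of 2-hydroxyphenyl on a carbon with a double bond to nitrogen.

Within the data shown here, only one measured step bears on this: a 28-fold higher number from compound 1 to compound 2 (1.45 log units; beyond the scatter), with nitro in place of hydroxy on an aromatic carbon. Compound 3 also gives up the hydroxy, so this large step points upward. It is an imperfect guide, however. Among the measured compounds shown here, compound 2 carries a nitro, compound 3 carries a methyl, and no measured compound shows what a methyl does here. A clear rise in this assay is therefore expected, probably smaller than the measured step, and the expected size is an 11-fold higher number from compound 1 to compound 3 (1.05 log units; beyond the scatter). For compound 3 the estimated value is 40 ug/mL, with an expected range from 8 ug/mL to 100 ug/mL.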

Compound 3, half-maximal cytotoxic concentration: 80.1 ug/mL
Compound 3: middle estimate off by 2.0-fold (0.30 log units), on the low side; measured number inside the range.
By their numbers in this assay, from the lowest: compound 1; then compounds 3 and 2 (each within the scatter of the next).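

Read in this assay, a 22-fold higher number from compound 1 to compound 3 (1.35 log units; beyond the scatter) shows that the large rise does not depend on a nitro group: replacing 2-hydroxyphenyl with 4-methylphenyl, which carries only carbon in its added group, also moves the number far from that of compound 1. Compound 3 and compound 2 lie within the scatter of each other, so these two quite different replacements cannot be ranked, and among the compounds shown, compound 1, the only one with the hydroxy, stands alone at the more toxic end. No measurement shown here explains this difference in toxicity.

The change from 2-hydroxyphenyl to 4-methylphenyl removes the hydroxy, adds a methyl and alters the group's place on the ring all at once, so the separate part played by each remains unresolved. A compound with a methoxy group or an amine in place of the hydroxy, or one with a plain phenyl ring, would help show whether the low number of compound 1 is specific to the hydroxy.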